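Methoxy in place of tert-butyl: series notes

The source may report more compounds than this note shows. Statements on the series, on what has been measured and on what is new or still open speak of the compounds shown alone.

In a functional assay on MCF-10A cells (Homo sapiens) for antiproliferative activity, with a stated time of 48 h (on this read-out higher numbers stand for an effect only at larger amounts of compound and lower numbers for an effect already at smaller amounts), compound 1 (`COc1ccc2nc(C)cc(NCc3ccccc3)c2c1`) gives 25900 nM. Compound 2 (`COc1ccc2nc(C)cc(NCc3ccc(C(C)(C)C)cc3)c2c1`) gives 6900 nM, and compound 3 (`COc1ccc2nc(C)cc(NCc3ccccc3F)c2c1`) gives 14000 nM. Compound 2 therefore holds the lowest of the three numbers, and the values of the other two lie beyond the scatter from it.

Compound 4 (`COc1ccc(CNc2cc(C)nc3ccc(OC)cc23)cc1`) carries methoxy in place of tert-butyl on an aromatic carbon, para to a large group: methoxy in place of tert-butyl on an aromatic carbon.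

Among the measured compounds shown here, two measured steps bear on this change, both only indirectly, as neither introduces methoxy. The tert-butyl step is a 3.8-fold lower number from compound 1 to compound 2 (0.57 log units; beyond the scatter), which is modest but beyond the scatter. The fluoro step is a 1.9-fold lower number from compound 1 to compound 3 (0.27 log units; within the scatter), which stays within the scatter. Removing tert-butyl could therefore give up some or all of the gain seen for compound 2, and the value of compound 1 at 25900 nM marks the level expected if methoxy matched hydrogen. For the measured compounds named here, no measured compound shows how methoxy itself behaves, so a partial return towards that level is assumed.

The expected change is a 1.9-fold higher number from compound 2 to compound 4 (0.28 log units; within the scatter), a modest step towards a higher number in this assay. The estimate for compound 4 is 13000 nM, with an expected range from 5500 nM to 30000 nM.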

Compound 4, half-maximal effective concentration: 7000 nM
The estimate for compound 4 lay 1.9-fold (0.27 log units) above the measured number, within the range that was stated.
By their numbers in this assay, from the lowest: compounds 2, 4, 3 and 1 (each within the scatter of the next, the first and the last beyond it).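

In this assay, methoxy in place of tert-butyl on an aromatic carbon gives a 1.0-fold higher number from compound 2 to compound 4 (0.01 log units; within the scatter), so at this place on the six-membered aromatic ring of carbon only, the two groups cannot be told apart on this read-out, although methoxy brings 2 heavy atoms and 1 hydrogen-bond acceptor where tert-butyl brings 4 heavy atoms and no acceptor. Methoxy in place of hydrogen gives a 3.7-fold lower number from compound 1 to compound 4 (0.57 log units; beyond the scatter), the first direct reading for methoxy in the series, which shows that the step away from compound 1 at this place is not confined to tert-butyl. The compounds shown give no measured basis for explaining why these two different groups read alike here.

On these data alone, whether the level shared by compound 2 and compound 4 also holds for a hydroxyl group, an amine or a carboxylic acid at this place remains open, as does the outcome for a longer chain such as ethoxy. As far as these compounds go, it is also open whether methoxy would give a similar step at another place on the same ring, as the two methoxy steps cover only this one place.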